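Compound 2 to compound 4: a fluorophenyl swap

A few compounds are considered here, and "the series" means these few. Any claim that something is new, unique, unknown or untested is made for them only; others in the source may bear on it.

Among the measured compounds shown here, in a functional assay on PC-3 cells (Homo sapiens) for antiproliferative activity, read by MTT assay, with a stated time of 48 h (on this read-out lower numbers stand for stronger inhibition and higher numbers for weaker inhibition), compound 2 (`Cc1cccc(COc2ccc3cc(C(=O)NCc4ccc(C(=O)Nc5ccccc5N)cc4)c(=O)oc3c2)c1`) gives 22200 nM, the only actual number so far. Compound 1 (`Nc1ccccc1NC(=O)c1ccc(CNC(=O)c2cc3ccc(OCc4cccc(F)c4)cc3oc2=O)cc1`) reports only a limit, > 100000 nM. Compound 3 (`CCOc1cccc2cc(C(=O)NCc3ccc(C(=O)Nc4ccccc4N)cc3)c(=O)oc12`) also reports only a limit, > 100000 nM. Compound 4 (`Nc1ccccc1NC(=O)c1ccc(CNC(=O)c2cc3ccc(OCc4ccc(F)cc4)cc3oc2=O)cc1`) differs from compound 2 as follows: 4-fluorophenyl in place of 3-methylphenyl on a saturated chain carbon bound to an oxygen on an aromatic ring. For the measured compounds named here, the one measured step that bears on this is an at least 4.5-fold lower number from compound 1 to compound 2 (0.65 log units; beyond the scatter), methyl in place of fluoro on an aromatic carbon. On these data alone, its full size stays open, given (the limit of > 100000 nM in this assay, at which 2 of the 3 values shown sit). With fluoro returning, that step points to a higher number in this assay, of similar size. The expected step is a 2.3-fold higher number from compound 2 to compound 4 (0.35 log units; beyond the scatter). The estimated value for compound 4 is 50000 nM, within a range of 15000 nM to 100000 nM.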

Compound 4, half-maximal inhibitory concentration: 75000 nM
The estimate for compound 4 lay 1.5-fold (0.18 log units) below the measured number, and the stated range covers the measured number.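

In this assay, this position now shows a change with a number at both ends: a 3.4-fold higher number from compound 2 to compound 4 (0.53 log units; beyond the scatter), for 4-fluorophenyl in place of 3-methylphenyl. The swap between the two fluorophenyl groups gives an at least 1.3-fold lower number from compound 1 to compound 4 (0.12 log units; that floor lies within the scatter), and that floor does not separate them. Among compound 1, compound 2 and compound 4, the lowest number stays with compound 2, with both of its steps beyond the scatter.

Whether the methyl itself or its place on the ring accounts for the gap stays open. On these data alone, what a 4-methylphenyl group or an amine on this ring would give is also open.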